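Swapping the aryl imine arm of a thiosemicarbazide series

The source may report more compounds than this note shows. Statements on the series, on what has been measured and on what is new or still open speak of the compounds shown alone.

Measured compounds:
- Compound 1, `CC1=CC[C@@H]([C@@](C)(O)CCCC(C)(C)NC(=S)N/N=C\c2ccc(O)cc2)CC1` — 58500 nM
- Compound 2, `CC1=CC[C@@H]([C@@](C)(O)CCCC(C)(C)NC(=S)N/N=C\c2ccc(Cl)cc2)CC1` — 47300 nM

Both compounds were tested in a functional assay on HT-29 cells (Homo sapiens) for cytotoxicity, read by sulforhodamine B assay; on this read-out lower numbers stand for higher toxicity in this test and higher numbers for lower toxicity in this test. Compound 1 gives 58500 nM, and compound 2 gives 47300 nM. Compound 2 therefore stands at the lower of the two numbers, but the step of a 1.2-fold lower number from compound 1 to compound 2 (0.09 log units; within the scatter) is within the scatter, so the two compounds cannot be told apart on this read-out.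

Compound 3, `CC1=CC[C@@H]([C@@](C)(O)CCCC(C)(C)NC(=S)N/N=C(/C)c2ccccc2)CC1`, has not yet been measured. It differs from compound 2 by a group of 9 heavy atoms (8 carbon, 1 nitrogen; one six-membered aromatic ring of carbon only) in place of a group of 9 heavy atoms (7 carbon, 1 nitrogen, 1 chlorine; one six-membered aromatic ring of carbon only), on an amide-type nitrogen. For the measured compounds named here, the only measured step, a 1.2-fold lower number from compound 1 to compound 2 (0.09 log units; within the scatter), changes a substituent on the aromatic ring, not the group on the amide-type nitrogen, so it bears only loosely on this change; it shows that the shared core tolerates one aromatic-ring alteration without a shift beyond the scatter. With no step beyond the scatter on record, the expectation for compound 3 is a step of about a 1.1-fold higher number from compound 2 to compound 3 (0.02 log units; within the scatter) in this assay, that is, none beyond the scatter. Compound 3 is thus estimated at 50000 nM, with a range from 20000 nM to 125000 nM.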

Compound 3, concentration lethal to 50% of the cells: > 100000 nM
Compound 3: a limit, no number; the forecaster's own chance of this, stated with the estimate: 10%; middle value at least 2.0-fold (0.30 log units) from the limit.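

In this assay compound 3 gives > 100000 nM as its reading, which is a limit of the assay and not a number. The earlier step changed only a substituent on the aromatic ring and stayed within the scatter, whereas the change on the amide-type nitrogen, where a group of 9 heavy atoms (8 carbon, 1 nitrogen) replaces one of 9 heavy atoms (7 carbon, 1 nitrogen, 1 chlorine), gives an at least 2.1-fold higher number from compound 2 to compound 3 (0.32 log units; beyond the scatter) and so shows that the read-out can respond to a change at this place. On these data alone, the comparison with the hydroxy-bearing partner is less firm, at an at least 1.7-fold higher number from compound 1 to compound 3 (0.23 log units; that floor lies within the scatter) and with no upper bound, so the shift is established only against the chloro-bearing compound and its full size remains unknown.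

The compounds shown leave open whether the shift goes with the loss of the ring substituent or with the added carbon of the entering group, as no compound here carries one change without the other. Also open, as far as these compounds go, is how a methoxy group or a nitrile on the aromatic ring would read in this assay on this shared core.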